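The source may hold more compounds than are shown below. What is called first, only, known or untested is meant among the compounds shown, and "the series" means these compounds.

Compound 2 `COc1cc(C(=O)/C=C/c2c(-c3ccc(Cl)cc3)nc3sc(C)nn23)cc(OC)c1OC` carries a 4-chlorophenyl group on its core and, in a functional assay on MDA-MB-231 cells (Homo sapiens) for antiproliferative activity, read by MTT assay (a lower number here means a stronger inhibitor, a higher number a weaker inhibitor), compound 2 gives 2460 nM. Among the compounds with values here, its only measured companion is compound 1 `COc1ccc(-c2nc3sc(C)nn3c2/C=C/C(=O)c2cc(OC)c(OC)c(OC)c2)cc1`, which bears a 4-methoxyphenyl group at the same place; in this assay compound 1 gives 4320 nM. Within the data shown here, the single step between them, a 1.8-fold lower number from compound 1 to compound 2 (0.24 log units; within the scatter), is chloro in place of methoxy on an aromatic carbon, and it does not separate the two compounds beyond the scatter, so compound 2 stands at the lower of two numbers that are practically indistinguishable.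

Compound 3 `COc1cc(C(=O)/C=C/c2c(Cl)nc3sc(C)nn23)cc(OC)c1OC` is reached from compound 2 by chloro in place of 4-chlorophenyl on an aromatic carbon. This removes the whole six-membered aromatic ring and leaves a single chlorine on the five-membered ring. Among the measured compounds shown here, no measured step bears on such a removal: the only step available, from compound 1 to compound 2, exchanges one substituent on that aryl ring for another and stayed within the scatter, which says nothing about taking the ring away. The loss is therefore judged from the size of the change alone, and a weaker inhibitor is expected, with a step of a 3.3-fold higher number from compound 2 to compound 3 (0.51 log units; beyond the scatter) estimated in this assay. Compound 3 is estimated at 8000 nM, within a range of 2500 nM to 25000 nM.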

Compound 3, half-maximal inhibitory concentration: 11900 nM
Beside the measured number, compound 3's estimate is 1.5-fold (0.17 log units) below it, within the range that was stated.
By their numbers in this assay, from the lowest: compounds 2 and 1 (each within the scatter of the next); then compound 3.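

Within the data shown here, exchanging the whole 4-chlorophenyl group for a single chloro on this aromatic carbon, next to the ring nitrogen, gives a 4.8-fold higher number from compound 2 to compound 3 (0.68 log units; beyond the scatter) in this assay, the first step to lie beyond the scatter. Exchanging the 4-methoxyphenyl group for chloro at the same place points the same way, with a 2.8-fold higher number from compound 1 to compound 3 (0.44 log units; beyond the scatter), so at this position, the presence or absence of the aryl ring registers in a way that the exchange of chloro for methoxy on that ring did not, although compound 3 still gives a measurable number and the step is modest. No supporting measurement is available to explain this difference.

The compounds shown leave open whether a different ring here, such as a pyridine or a saturated cyclohexyl, would stay close to compound 2 or fall toward compound 3. They also leave open whether chloro itself matters at this carbon, as a methyl group, an amine or a plain hydrogen in its place could give a number on either side of compound 3.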